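This account rests on a few compounds, and the source may have more. Where it says the series, first, only, none or still open, it means among the compounds named here.

Measured compounds in a functional assay on DU-145 cells (Homo sapiens) for cytotoxicity, read by MTT assay, with a stated time of 48 h; a lower number here means a stronger inhibitor, a higher number a weaker inhibitor:
compound 1 `COc1cc(COCc2cn(Cc3cc(-c4ccccc4)cnc3Cl)nn2)cc(OC)c1OC` gives 45500 nM
compound 2 `COc1cc(COCc2cn(Cc3cc(-c4ccc(F)cc4)cnc3Cl)nn2)cc(OC)c1OC` gives 38800 nM
compound 3 `COc1cc(C2=NOC(COCc3cn(Cc4cc(-c5ccccc5)cnc4Cl)nn3)C2)cc(OC)c1OC` gives 11400 nM

Compound 2 stands second highest of the three numbers. Among the measured compounds shown here, its nearest neighbour is compound 1, and the only single-point step measured so far, a 1.2-fold lower number from compound 1 to compound 2 (0.07 log units; within the scatter), lies within the scatter, so compound 1 and compound 2 cannot be ordered against each other. For the measured compounds named here, compound 3 gives the lowest number of the three, beyond the scatter from compound 2, but it differs from compound 2 in more than one place and no single step connects them.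

Compound 4 `COc1cc(COCc2cn(Cc3cc(C)cnc3Cl)nn2)cc(OC)c1OC` is the next compound for this assay. Relative to compound 2 the change is methyl in place of 4-fluorophenyl on an aromatic carbon.

Going by the values given here, no measured step bears directly on this change. Among the compounds with values here, the one step on record, a 1.2-fold lower number from compound 1 to compound 2 (0.07 log units; within the scatter), concerns only the fluoro of the 4-fluorophenyl and was within the scatter; it says nothing about taking the whole 4-fluorophenyl away in favour of a methyl. Compound 3 varies a different part of the shared core. Within the data shown here, with no anchoring step, the expectation for compound 4 is a moderate move toward a higher number, a 1.8-fold higher number from compound 2 to compound 4 (0.26 log units; within the scatter), held with wide uncertainty, and it is not certain to clear the scatter.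

Compound 4 is therefore estimated at 70000 nM, with a range from 25000 nM to 200000 nM.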

Compound 4, half-maximal inhibitory concentration: 34800 nM
Beside the measured number, compound 4's estimate is 2.0-fold (0.30 log units) above it; the measured number falls inside the stated range.
By their numbers in this assay, from the lowest: compound 3; then compounds 4, 2 and 1 (each within the scatter of the next).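

In this assay, the aromatic carbon two atoms from the ring nitrogen and para to a chloro group shows no readable response to losing the whole aromatic ring: methyl in place of 4-fluorophenyl gives a 1.1-fold lower number from compound 2 to compound 4 (0.05 log units; within the scatter), and methyl in place of phenyl gives a 1.3-fold lower number from compound 1 to compound 4 (0.12 log units; within the scatter). The earlier fluoro step concerned only a substituent on that ring, whereas these two steps show that replacing the entire six-membered aromatic ring of carbon only with a methyl also stays within the scatter, so compounds 1, 2 and 4 cannot be ordered against each other. Nothing on hand explains why the number stays within the scatter across these changes.

Open, from the compounds shown here alone, is whether a group of another kind at this position, such as an amine, a carboxylic acid or a longer alkyl chain, would give a step beyond the scatter, as phenyl, 4-fluorophenyl and methyl have not so far. Also open, going by these compounds, is whether methyl in place of phenyl on the core of compound 3 would likewise stay within the scatter.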